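The compounds below may be only part of what the source reports. "The series", "measured", "known", "first", "only" and "open" are said of these compounds alone.

In an ADME assay on HeLa cells (Homo sapiens) for cytotoxicity, with a stated time of 72 h (a higher number here means that more compound is tolerated, a lower number that less compound is tolerated), compound 1 `CC(C)C[C@@H](N)C(=O)Nc1ccc(NC(=O)/C=C/c2ccc(-c3ccc([N+](=O)[O-])cc3)o2)cc1C(=O)c1ccccc1` gives 47800 nM. Compound 2 `CSCC[C@H](N)C(=O)Nc1ccc(NC(=O)/C=C/c2ccc(-c3ccc([N+](=O)[O-])cc3)o2)cc1C(=O)c1ccccc1` gives > 81000 nM, which is a limit of the assay and not a number. Compound 3 `CSCC[C@@H](N)C(=O)Nc1ccc(NC(=O)/C=C/c2ccc(-c3ccc([N+](=O)[O-])cc3)o2)cc1C(=O)c1ccccc1` differs from compound 2 in configuration only: the two compounds have the same atoms and bonds and differ only in configuration as drawn: 1 of 2 stereo elements differ; a stereocentre at a saturated chain carbon is drawn S in compound 2 and R in compound 3. Going by the values given here, the one measured step, an at least 1.6-fold higher number from compound 1 to compound 2 (0.22 log units; that floor lies within the scatter), swaps the group on a carbonyl carbon rather than a configuration, and its floor lies within the scatter, so it offers only an indirect guide. No step beyond the scatter is expected in this assay, the estimated step being an at least 1.0-fold lower number from compound 2 to compound 3 (0.03 log units; that floor lies within the scatter). For compound 3 the expected value is 75000 nM, with an estimated range of 40000 nM to 130000 nM.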

Compound 3, half-maximal cytotoxic concentration: > 81000 nM
Compound 3 gave a limit, no number; the forecaster's own chance of this, stated with the estimate: 45%; at least 1.0-fold (0.03 log units) between middle value and limit.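

In this assay, inverting the stereocentre at the saturated chain carbon gives no readable step, since compound 2 and compound 3 both stop at a limit and not a number: the limit of > 81000 nM in this assay, at which 2 of the 3 values shown sit. With the configuration drawn R, the group swap reads as an at least 1.6-fold higher number from compound 1 to compound 3 (0.22 log units; that floor lies within the scatter), so the floor seen with the S configuration also appears with R.

Still open, on these data alone, is how far compound 2 and compound 3 lie apart past the limit, and what a longer chain or a carboxylic acid on this saturated chain carbon would give in this assay.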